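Pyrazinyl for pyridinyl on the hydrazone carbon

This account rests on a few compounds, and the source may have more. Where it says the series, first, only, none or still open, it means among the compounds named here.

Compound 3 `C/C(=N\Nc1nc2ccccc2o1)c1ccccn1` gives 132 nM in a functional assay on HT-29 cells (Homo sapiens) for antiproliferative activity, read by sulforhodamine B assay (a higher number here means a weaker inhibitor, a lower number a stronger inhibitor), the lowest number of the three measured compounds; compound 1 `CC(C)/C(=N\Nc1nc2ccccc2o1)c1ccccn1` gives 645 nM and compound 2 `c1ccc(/C(=N/Nc2nc3ccccc3o2)C2CC2)nc1` gives 20600 nM. The measured steps, a 4.9-fold lower number from compound 1 to compound 3 (0.69 log units; beyond the scatter) and a 160-fold lower number from compound 2 to compound 3 (2.19 log units; beyond the scatter), both alter the group on the carbon with a double bond to nitrogen, as does a 32-fold higher number from compound 1 to compound 2 (1.50 log units; beyond the scatter). Compound 4 `C/C(=N\Nc1nc2ccccc2o1)c1cnccn1` instead alters the aromatic ring: pyrazin-2-yl in place of pyridin-2-yl on a carbon with a double bond to nitrogen. Going by the values given here, the ring is kept unchanged in all three measured compounds, so no measured step bears directly on this exchange and the steps give no guide to its size or direction. For compound 4 a step within the scatter, or a modest weakening, is therefore expected: a 1.9-fold higher number from compound 3 to compound 4 (0.28 log units; within the scatter). Compound 4 is estimated at 250 nM, within 80 nM to 800 nM.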

Compound 4, half-maximal inhibitory concentration: 340 nM
For compound 4 the middle estimate is 1.4-fold (0.13 log units) below the measured one; the range from low to high includes it.
By their numbers in this assay, from the lowest: compound 3; then compounds 4 and 1 (each within the scatter of the next); then compound 2.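

Changing the aromatic ring on the carbon with a double bond to nitrogen is itself enough to shift the number in this assay, with a 2.6-fold higher number from compound 3 to compound 4 (0.41 log units; beyond the scatter), so this place responds to the ring as well as to the alkyl group. The step is modest beside the largest alkyl steps, and pyrazin-2-yl keeps the ring size of pyridin-2-yl while adding a ring nitrogen. Nothing at hand accounts for this step.

From the compounds shown here alone, whether the same weakening holds with isopropyl or cyclopropyl in place of methyl remains open. Also open, going by these compounds, is how a phenyl or pyrimidin-2-yl ring would read here.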